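The source may report more compounds than this note shows. Statements on the series, on what has been measured and on what is new or still open speak of the compounds shown alone.

In a functional assay with Oryctolagus cuniculus as the target (a lower number here means a stronger inhibitor, a higher number a weaker inhibitor), compound 1 `CNC(=N)Nc1nc(-c2ccc(OC)cc2)c(-c2ccc(OC)cc2)s1` gives 62 nM, and compound 2 `CNC(=O)NCc1nc(-c2ccc(OC)cc2)c(-c2ccc(OC)cc2)s1` gives 22 nM, the lower of the two numbers. Compound 3 `COc1ccc(-c2nc(C(=O)N3CCOCC3)sc2-c2ccc(OC)cc2)cc1` departs from compound 2 through ((morpholin-4-yl)carbonyl in place of ((methylcarbamoyl)amino)methyl on an aromatic carbon), so that (morpholin-4-yl)carbonyl stands in place of ((methylcarbamoyl)amino)methyl on an aromatic carbon. Going by the values given here, only one measured step bears on this, a modest one that also exchanged a group on an aromatic carbon: a 2.8-fold lower number from compound 1 to compound 2 (0.45 log units; beyond the scatter). A step of similar or somewhat larger size is expected, towards a higher number, though the direction is uncertain. The expected step is a 3.2-fold higher number from compound 2 to compound 3 (0.50 log units; beyond the scatter). For compound 3 the estimated value is 70 nM, within a range of 12 nM to 400 nM.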

Compound 3, half-maximal inhibitory concentration: < 10 nM
Compound 3 ended at the assay's limit (the forecaster's own chance of this, stated with the estimate: 3%); middle value at least 7.0-fold (0.84 log units) away from the limit.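

In this assay compound 3 stands as a limit and not as a number: the limit of < 10 nM in this assay, at which 1 of the 3 values shown sits.

At this position, on the aromatic carbon of the five-membered ring, (morpholin-4-yl)carbonyl gives an at least 2.2-fold lower number from compound 2 to compound 3 (0.34 log units; beyond the scatter), and the wider exchange gives an at least 6.2-fold lower number from compound 1 to compound 3 (0.79 log units; beyond the scatter). The earlier compounds shown here carried only groups with no ring here, whereas compound 3 shows that a six-membered non-aromatic ring with 0 hydrogen-bond donors goes with a lower number.

As far as these compounds go, the true size of both steps remains open. So does whether a piperidine amide or a carboxylic acid at this position would give a similar number.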